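Inverting One Ring Stereocentre on a Shared Core

A few compounds are considered here, and "the series" means these few. Any claim that something is new, unique, unknown or untested is made for them only; others in the source may bear on it.

compound 1 `CO[C@@H]1[C@@H](O)[C@@H](O)[C@H]2O[C@]1(C)n1c3ccccc3c3c4c(c5c6ccccc6n2c5c31)C(=O)N[C@@H]4O` — > 2500 nM
compound 2 `CO[C@@H]1[C@H](NC=O)C[C@H]2O[C@]1(C)n1c3ccccc3c3c4c(c5c6ccccc6n2c5c31)C(=O)NC4` — > 2500 nM

Of the compounds shown here, two have been measured in an assay on isolated protein for inhibition of protein kinase C theta type (Homo sapiens), read by HTRF; on this read-out lower numbers stand for stronger inhibition and higher numbers for weaker inhibition. Compound 1 gives only a limit of the assay, > 2500 nM. Compound 2 likewise gives only a limit, > 2500 nM. So compound 1 stands nowhere on a measured scale; all that is known is the boundary itself: the limit of > 2500 nM in this assay, at which 2 of the 2 values shown sit. Compound 3 `CO[C@@H]1[C@@H](O)[C@@H](O)[C@H]2O[C@]1(C)n1c3ccccc3c3c4c(c5c6ccccc6n2c5c31)C(=O)N[C@H]4O` is the next candidate. Compared with compound 1, (the two compounds have the same atoms and bonds and differ only in configuration as drawn: 1 of 6 stereo elements differ; a stereocentre at a saturated ring carbon is drawn R in compound 1 and S in compound 3). Among the measured compounds shown here, no pair of measured compounds differing in one place is available, so the size of such a step cannot be read from measured data. The step from compound 1 to compound 3 is expected to be none beyond the usual scatter, an expected step that the limit leaves unreadable from compound 1 to compound 3, leaving compound 3 most likely at the limit of this assay as well. Compound 3 is therefore estimated at 4000 nM, in a range of 800 nM to 20000 nM.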

Compound 3, half-maximal inhibitory concentration: 2250 nM
Beside the measured number, compound 3's estimate is 1.8-fold (0.25 log units) above it, within the range that was stated.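

In this assay compound 3 gives 2250 nM, the only value among the three shown that is a number on the scale and not a limit, and this number comes with no change to the shared core other than one inverted stereocentre: the fact that compounds 1 and 3 differ only in the configuration as drawn Compound 1 gives > 2500 nM, which is a limit of the assay. Redrawing the saturated ring carbon from R to S therefore gives only a floor for the step, an at least 1.1-fold lower number from compound 1 to compound 3 (0.04 log units; that floor lies within the scatter), and that floor does not separate the two compounds.

Going by these compounds, the true size of the step stays open while one end of it is a limit. Also open, on these data alone, is whether an amine or a methyl ether on this same saturated ring carbon would give a measured number in this assay, and whether its R and S forms would then differ.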